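The compounds below may be only part of what the source reports. "The series", "measured", "known", "first", "only" and "open" are said of these compounds alone.

Measured compounds in the series:
compound 1 `CCN(CC)C(=O)C(C)N1CCN(S(=O)(=O)c2ccc(C(C)(C)C)cc2)CC1`
compound 2 `CC(C(=O)N1CCCCCC1)N1CCN(S(=O)(=O)c2ccc(C(C)(C)C)cc2)CC1`
compound 3 `CC(C(=O)N1CCC2(CC1)CC2)N1CCN(S(=O)(=O)c2ccc(C(C)(C)C)cc2)CC1`

In an ADME assay on HepG2 cells (Homo sapiens) for inhibition, with a stated time of 48 h (a higher number here means that more compound is needed for the effect, a lower number that less compound is needed), compound 1 gives only a limit, > 40000 nM. In this assay compound 2 likewise gives only a limit, > 40000 nM. Compound 3 also gives only a limit in this assay, > 40000 nM. Compound 3 thus has no number of its own; it stands at the limit of > 40000 nM in this assay, at which 3 of the 3 values shown sit, together with the two other measured compounds.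

The measured steps that change the amide substituent on the carbonyl carbon are all unreadable for the same reason: a step that the two limits leave unreadable from compound 1 to compound 2, a step that the two limits leave unreadable from compound 1 to compound 3 and a step that the two limits leave unreadable from compound 2 to compound 3. None of them shows a size or a direction.

Compound 4 `CC(C(=O)N(C)Cc1ccccc1)N1CCN(S(=O)(=O)c2ccc(C(C)(C)C)cc2)CC1` differs from compound 3 by a group of 9 heavy atoms (8 carbon, 1 nitrogen; one six-membered aromatic ring of carbon only) in place of a group of 8 heavy atoms (7 carbon, 1 nitrogen; one three-membered non-aromatic ring of carbon only, one six-membered non-aromatic ring with 1 hetero atom), on a carbonyl carbon. The three measured steps bear on this change only in that every variation of the amide group so far has left the value at the limit. No step size can therefore be expected from the data; the working expectation is that compound 4 remains at the limit as well. Compound 4 is estimated at 60000 nM, with a range from 30000 nM to 200000 nM, and the step that the limit leaves unreadable from compound 3 to compound 4 is expected to be no more than nominal.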

Compound 4, half-maximal effective concentration: > 40000 nM
Compound 4: no number, only a limit; the forecaster's own chance of this, stated with the estimate: 85%; the middle value lies beyond the limit too.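

In this assay compound 4 also gives only a limit, > 40000 nM. No step from compound 1, compound 2 or compound 3 to compound 4 can be read: the limit of > 40000 nM in this assay, at which 4 of the 4 values shown sit.

Left open is whether any amide group on the carbonyl carbon would give a measurable value in this assay.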